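The source may hold more compounds than are shown below. What is called first, only, known or untested is meant among the compounds shown, and "the series" means these compounds.

Measured so far:
compound 1, `O=C(O)/C(S)=C/c1c[nH]c2cc(Br)ccc12`: 7 nM
compound 2, `O=C(O)/C(S)=C/c1c[nH]c2cc(I)ccc12`: 170 nM
compound 3, `O=C(O)/C(S)=C/c1ccccc1Br`: 21000 nM

All three were tested in an assay on isolated protein for inhibition of Calpain-1 catalytic subunit (Sus scrofa), read by FRET; on this read-out higher numbers stand for weaker inhibition and lower numbers for stronger inhibition. Compound 1 gives the lowest number of the three; the change iodo in place of bromo on an aromatic carbon made a step of a 24-fold higher number from compound 1 to compound 2 (1.39 log units; beyond the scatter). Compound 3 stands highest of the three, far from both compound 2 and compound 1. How the core of compound 3 differs from the core of compound 1 is not broken down here.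

Compound 4, `O=C(O)/C(S)=C/c1ccccc1I`, is still to be measured in this assay. It differs from compound 3 by iodo in place of bromo on an aromatic carbon. Among the measured compounds shown here, this is the same kind of change as the one from compound 1 to compound 2, but the place is not the same: in compound 1 the ring is part of a fused or bridged system of two rings, meta to a fused ring and para to a fused ring, whereas in compound 3 the ring carbon is ortho to a group of 6 heavy atoms.

Resting on a 24-fold higher number from compound 1 to compound 2 (1.39 log units; beyond the scatter), compound 4 is expected to give a higher number than compound 3, a step of about a 9.5-fold higher number from compound 3 to compound 4 (0.98 log units; beyond the scatter), somewhat smaller on this different core. The estimate for compound 4 in this assay is 200000 nM, expected between 50000 nM and 800000 nM.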

Compound 4, half-maximal inhibitory concentration: 29600 nM
For compound 4 the middle estimate is 6.8-fold (0.83 log units) above the measured one; the whole stated range lies above it.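

In this assay, iodo in place of bromo on an aromatic carbon gave a 1.4-fold higher number from compound 3 to compound 4 (0.15 log units; within the scatter), so on this core the two halogens cannot be told apart. Set beside the earlier case, the change does not carry over in size from one core to the other: the same change on two cores in this assay, a 24-fold higher number (1.39 log units; beyond the scatter) from compound 1 to compound 2 and a 1.4-fold higher number (0.15 log units; within the scatter) from compound 3 to compound 4, 17-fold (1.24 log units) apart, beyond the scatter of two such steps. This does not show what sets the two steps apart, as the two pairs differ both in the core and in the place of the halogen, and two pairs say nothing about how the change would behave on a third core.

The compounds shown leave open whether a chloro, a fluoro or a methoxy group on the same aromatic carbon would follow the bromo or the iodo compounds on either core. They also leave open whether the large step on the core of compound 1 would persist with the halogen elsewhere on that core.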